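This account rests on a few compounds, and the source may have more. Where it says the series, first, only, none or still open, it means among the compounds named here.

Working notes on the series.

Compound 1 `COc1ccc(/C=C/C(=O)c2ccccc2-c2ccc(F)cc2)cc1OC` is the reference. In a functional assay on MCF7 cells (Homo sapiens) for antiproliferative activity, read by sulforhodamine B assay, with a stated time of 48 h (on this read-out higher numbers stand for weaker inhibition and lower numbers for stronger inhibition), compound 1 gives 240 nM. Compound 2 `COc1ccc(/C=C/C(=O)c2ccccc2-c2ccc(F)nc2)cc1OC` keeps the core of compound 1 and differs in one place (6-fluoropyridin-3-yl in place of 4-fluorophenyl on an aromatic carbon). In this assay compound 2 gives 2800 nM, and the step is a 12-fold higher number from compound 1 to compound 2 (1.07 log units; beyond the scatter).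

Compound 3 `COc1ccc(C(=O)/C=C/c2ccccc2-c2ccc(F)cc2)cc1OC` carries the same atoms as compound 1, joined differently; the difference between the two cores is not broken down here. In this assay compound 3 gives 7100 nM, the highest number of the three measured compounds, beyond the scatter from both compound 1 and compound 2.

Compound 4 `COc1ccc(C(=O)/C=C/c2ccccc2-c2ccc(F)nc2)cc1OC` is not yet measured. It stands to compound 3 as compound 2 stands to compound 1: 6-fluoropyridin-3-yl in place of 4-fluorophenyl on an aromatic carbon. The place of the change reads the same in both pairs, so this is the same change made on the other core. The change has occurred only once so far among the compounds shown, so its transfer to the core of compound 3 rests on a single step.

For compound 4 the expected step is an 8.5-fold higher number from compound 3 to compound 4 (0.93 log units; beyond the scatter), taken to be of about the size of the measured step, because compound 1 to compound 2 shows a 12-fold higher number from compound 1 to compound 2 (1.07 log units; beyond the scatter). Compound 4 is therefore estimated at 60000 nM in this assay, with a plausible range from 15000 nM to 250000 nM, and the value may well reach the top of the tested concentrations.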

Compound 4, half-maximal inhibitory concentration: 41000 nM
Beside the measured number, compound 4's estimate is 1.5-fold (0.17 log units) above it; the range from low to high includes it.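

The change from 4-fluorophenyl to 6-fluoropyridin-3-yl again gives weaker inhibition on the second core: in this assay, the new step is a 5.8-fold higher number from compound 3 to compound 4 (0.76 log units; beyond the scatter). Set beside the earlier step, it points the same way, and the two steps do not differ by more than the scatter allows: the same change on two cores in this assay, a 12-fold higher number (1.07 log units; beyond the scatter) from compound 1 to compound 2 and a 5.8-fold higher number (0.76 log units; beyond the scatter) from compound 3 to compound 4, 2.0-fold (0.31 log units) apart, within the scatter of two such steps. Among the compounds shown here, this supports carrying the change between the core of compound 1 and the core of compound 3 as a loss of inhibition of similar size, but it rests on only two pairs and does not show why the change weakens inhibition or whether it would carry to any other core.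

The compounds shown hold only these two groups at this place on the ring, so it remains open how a plain phenyl, a pyridinyl ring without fluorine, or a ring with an amine or a methoxy group in place of the fluorine would behave on either core. As far as these compounds go, it also remains open whether the step keeps its direction and size in cells other than those of this assay.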